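Benzyl ring substitution on the shared core: a fluoro variant

The source may report more compounds than this note shows. Statements on the series, on what has been measured and on what is new or still open speak of the compounds shown alone.

Compound 1 `Cc1cc(Nc2cc(-c3ccccc3)[nH]n2)n2nc(SCc3ccc([N+](=O)[O-])cc3)nc2n1` gives 4250 nM in a functional assay on MGC-803 cells (Homo sapiens) for inhibition, read by MTT assay, with a stated time of 72 h; on this read-out higher numbers stand for weaker inhibition and lower numbers for stronger inhibition. Compound 2 `Cc1ccc(CSc2nc3nc(C)cc(Nc4cc(-c5ccccc5)[nH]n4)n3n2)cc1` gives 6960 nM in this assay, and compound 3 `Cc1cc(Nc2cc(-c3ccccc3)[nH]n2)n2nc(SCc3cccc(Br)c3)nc2n1` gives 4820 nM. Compound 2 differs from the other two only within the scatter, as the steps of a 1.6-fold higher number from compound 1 to compound 2 (0.21 log units; within the scatter) and a 1.4-fold lower number from compound 2 to compound 3 (0.16 log units; within the scatter) show; the step of a 1.1-fold higher number from compound 1 to compound 3 (0.05 log units; within the scatter) is also within the scatter. Compound 4 `Cc1cc(Nc2cc(-c3ccccc3)[nH]n2)n2nc(SCc3ccc(F)cc3)nc2n1` carries the change (fluoro in place of methyl on an aromatic carbon). Every measured exchange on this benzyl ring, whether nitro, methyl or bromo, left this assay unchanged beyond the scatter, so no step beyond the scatter is expected for compound 4 either, a 1.3-fold lower number from compound 2 to compound 4 (0.10 log units; within the scatter). Compound 4 is therefore estimated at 5500 nM, within 2500 nM to 12000 nM.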

Compound 4, half-maximal inhibitory concentration: 3270 nM
Compound 4: middle estimate off by 1.7-fold (0.23 log units), on the high side; measured number inside the range.
By their numbers in this assay, from the lowest: compounds 4, 1, 3 and 2 (each within the scatter of the next, the first and the last beyond it).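

Fluoro at this place gives the first step on the benzyl ring that lies beyond the scatter, though only a modest one (a 2.1-fold lower number from compound 2 to compound 4 (0.33 log units; beyond the scatter)). The other two steps stay within the scatter (a 1.5-fold lower number from compound 3 to compound 4 (0.17 log units; within the scatter); a 1.3-fold lower number from compound 1 to compound 4 (0.11 log units; within the scatter)), so in this assay only the fluoro and methyl pair is separated. Nothing on hand accounts for that gap. The compounds shown leave open whether an amine or a carboxylic acid on this ring, or a longer chain on the sulfur, moves the number further.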